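Adding a Second Chloro Group to Compound 3

This account rests on a few compounds, and the source may have more. Where it says the series, first, only, none or still open, it means among the compounds named here.

Of the compounds shown here, three built on one shared core have been tested in a functional assay on NCI-H1975 cells (Homo sapiens) for inhibition, read by MTT assay, with a stated time of 72 h; a higher number here means a weaker inhibitor, a lower number a stronger inhibitor. Compound 1 `CCc1cccc(NC(=O)CSc2nc(Nc3ccccc3)c3ccccc3n2)c1` gives 12000 nM, compound 2 `O=C(CSc1nc(Nc2ccccc2)c2ccccc2n1)Nc1ccc([N+](=O)[O-])cc1` gives 13000 nM, and compound 3 `C=CC(=O)Nc1cccc(NC(=O)CSc2nc(Nc3ccccc3Cl)c3ccccc3n2)c1` gives 10000 nM. Compound 3 has the lowest of these three numbers, yet its gaps to both others lie within the scatter, so the three cannot be told apart here. Within the data shown here, the only change between measured compounds, a 1.1-fold higher number from compound 1 to compound 2 (0.03 log units; within the scatter), swapped the group on an amide-type nitrogen. Compound 4 `C=CC(=O)Nc1cccc(NC(=O)CSc2nc(Nc3ccc(Cl)cc3Cl)c3ccccc3n2)c1` differs from compound 3 by chloro in place of hydrogen on an aromatic carbon. Among the measured compounds shown here, no measured step touches the (2-chlorophenyl)amino group, so the expectation rests on how little the numbers have moved so far. A step of no change at the digits printed from compound 3 to compound 4 (within the scatter) is expected, meaning nothing beyond the scatter. Compound 4 is therefore estimated at 10000 nM, within 4000 nM to 25000 nM.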

Compound 4, half-maximal inhibitory concentration: 5990 nM
Estimate against measurement, compound 4: 1.7-fold (0.22 log units) above; low and high end bracket the measured number.
By their numbers in this assay, from the lowest: compounds 4, 3, 1 and 2 (each within the scatter of the next, the first and the last beyond it).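

In this assay, this first measured change on the (2-chlorophenyl)amino group, chloro in place of hydrogen para to a large group, gives a 1.7-fold lower number from compound 3 to compound 4 (0.22 log units; within the scatter) and so does not separate the two compounds. This position therefore carries a second chloro group without a step beyond the scatter. No available evidence bears on this result.

Going by these compounds, whether a methoxy group or an amine at this place would give a step beyond the scatter remains open. So does whether chloro here would give a similar step without the 2-chloro group.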